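Extending the amine side chain in a sigma-1 binding series

The source may report more compounds than this note shows. Statements on the series, on what has been measured and on what is new or still open speak of the compounds shown alone.

Of the compounds shown here, three have been measured in an assay for displacement of a labelled ligand from Sigma non-opioid intracellular receptor 1 (Cavia porcellus), read by scintillation counting, with a stated time of 180 min; a higher number here means a weaker inhibitor, a lower number a stronger inhibitor. Compound 1 `Cn1ncc2c1CCOC21CCN(N2CCC(c3ccccc3)CC2)CC1` gives 7 nM. Compound 2 `COc1ccc(CN2CCC3(CC2)OC(OC)Cc2c3cnn2-c2ccccc2)cc1` gives 1.5 nM, and compound 3 `COC1Cc2c(cnn2-c2ccccc2)C2(CCN(Cc3ccco3)CC2)O1` gives 2.2 nM. On these numbers compound 3 sits second of the three: its nearest neighbour is compound 2, and the step of a 1.5-fold higher number from compound 2 to compound 3 (0.17 log units; within the scatter) lies within the scatter, so the two cannot be told apart. Compound 1 lies furthest from compound 3, and its number is higher by an amount beyond the scatter, though no single-point comparison links those two structures.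

Compound 4 `COC1Cc2c(cnn2-c2ccccc2)C2(CCN(CCCCc3ccccc3)CC2)O1` has not yet been measured. It differs from compound 3 in one place: 3-phenylpropyl in place of furan-2-yl on a saturated chain carbon bound to an amine nitrogen in a ring. Going by the values given here, only one measured step touches the same position, the exchange of the group on that carbon from compound 2 to compound 3, and it changed the number by an amount inside the scatter. That is thin evidence, but it suggests the position tolerates different groups without large shifts. For this assay the estimated step of a 1.1-fold lower number from compound 3 to compound 4 (0.04 log units; within the scatter) is therefore expected to stay within the scatter. Compound 4 is expected to give about 2 nM, with a likely range from 0.7 nM to 6 nM.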

Compound 4, inhibition constant: 3.2 nM
For compound 4 the middle estimate is 1.6-fold (0.20 log units) below the measured one; low and high end bracket the measured number.
By their numbers in this assay, from the lowest: compounds 2, 3 and 4 (each within the scatter of the next, the first and the last beyond it); then compound 1.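

Going by these compounds alone, until now, only two ring groups, furan-2-yl and 4-methoxyphenyl, had been compared on the saturated chain carbon bound to an amine nitrogen in a ring. In this assay the exchange of furan-2-yl, with 5 heavy atoms and 1 hydrogen-bond acceptor, for 3-phenylpropyl, with 9 heavy atoms and no acceptor, gives a 1.5-fold higher number from compound 3 to compound 4 (0.16 log units; within the scatter) and so cannot be told apart from no change. Within the data shown here, measured against 4-methoxyphenyl, however, the same group gives a 2.1-fold higher number from compound 2 to compound 4 (0.33 log units; beyond the scatter) and this modest step is the first at this position to pass beyond the scatter, so a phenyl ring carried on a chain is accepted here, though the comparison with compound 2 shows that the choice of group can register.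

The compounds shown leave open how a shorter chain such as 2-phenylethyl, a longer chain than 3-phenylpropyl, or an amine or a carboxylic acid at the end of the chain would fare at this position. Nothing available here explains why these groups give the numbers they do.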